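Swapping Trifluoromethyl for Methoxy on the Sulfonyl Aryl

The source may report more compounds than this note shows. Statements on the series, on what has been measured and on what is new or still open speak of the compounds shown alone.

Three compounds share one core and differ only in the aryl group attached to the sulfonyl sulfur. In a functional assay on PC-3 cells (Homo sapiens) for inhibition (on this read-out higher numbers stand for weaker inhibition and lower numbers for stronger inhibition), compound 1 `COc1cc2nc(N3CCN(S(=O)(=O)c4ccc(Cl)s4)CC3)nc(N)c2cc1OC` gives 25000 nM. In this assay compound 2 `COc1cc2nc(N3CCN(S(=O)(=O)c4cccc([N+](=O)[O-])c4)CC3)nc(N)c2cc1OC` gives 32000 nM, and compound 3 `COc1cc2nc(N3CCN(S(=O)(=O)c4ccc(C(F)(F)F)cc4)CC3)nc(N)c2cc1OC` gives 27000 nM. Compound 3 thus stands second highest of the three numbers, but every pairwise step is small: a 1.3-fold higher number from compound 1 to compound 2 (0.11 log units; within the scatter), a 1.1-fold higher number from compound 1 to compound 3 (0.03 log units; within the scatter) and a 1.2-fold lower number from compound 2 to compound 3 (0.07 log units; within the scatter). Exchanging one aryl group for another has so far left this assay essentially unchanged.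

Compound 4 `COc1ccc(S(=O)(=O)N2CCN(c3nc(N)c4cc(OC)c(OC)cc4n3)CC2)cc1` carries the change (methoxy in place of trifluoromethyl on an aromatic carbon). Among the measured compounds shown here, no measured step tests this exact exchange, but all three recorded aryl swaps stayed within the scatter, which is the only guide available. The step of a 1.0-fold higher number from compound 3 to compound 4 (0.02 log units; within the scatter) is therefore expected to be none beyond the scatter. On that basis compound 4 is estimated at 28000 nM in this assay, with a plausible range from 12000 nM to 65000 nM.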

Compound 4, half-maximal inhibitory concentration: 39000 nM
For compound 4 the middle estimate is 1.4-fold (0.14 log units) below the measured one; measured number inside the range.
By their numbers in this assay, from the lowest: compounds 1, 3, 2 and 4 (each within the scatter of the next).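

In this assay, the exchange of a single substituent on the aromatic ring, rather than of a whole aryl group, gives a 1.4-fold higher number from compound 3 to compound 4 (0.16 log units; within the scatter) and so stays within the scatter, even though trifluoromethyl leaves and methoxy brings in a hydrogen-bond acceptor. The whole-group comparisons read the same way, with a 1.2-fold higher number from compound 2 to compound 4 (0.09 log units; within the scatter) and a 1.6-fold higher number from compound 1 to compound 4 (0.19 log units; within the scatter) both also within the scatter, so the 4-methoxyphenyl group cannot be told apart from the three other aryl groups. Nothing measured here speaks to why these four compounds read alike (no supporting data are available).

Still open, as far as these compounds go, is whether any substituent in this place can move the number beyond the scatter, for example an amine or a carboxylic acid. Also open, from the compounds shown here alone, is what happens when a plain alkyl chain replaces the aryl group on the sulfonyl sulfur.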